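The source may hold more compounds than are shown below. What is called first, only, known or untested is meant among the compounds shown, and "the series" means these compounds.

In a functional assay on A549 cells (Homo sapiens) for cytotoxicity, read by colorimetric assay and MTT assay (on this read-out higher numbers stand for weaker inhibition and lower numbers for stronger inhibition), compound 1 (`COc1cc(OC)c2cc(-c3ccccc3)c(O)nc2c1`) gives 10000 nM and compound 2 (`CCN(CC)C(=O)Cn1c(=O)c(-c2ccc(OC)cc2)cc2c(OC)cc(OC)cc21`) gives 10000 nM. For the measured compounds named here, compound 3 (`COc1ccc(-c2cc3c(OC)cc(OC)cc3n(CC#N)c2=O)cc1`) gives 10000 nM, which leaves it level with compounds 1 and 2 at the digits reported, so no compound stands apart.

Compound 4 (`COc1ccc(-c2cc3c(OC)cc(OC)cc3n(CC(=O)OCc3ccccc3)c2=O)cc1`) is not yet measured. The change is benzyloxycarbonyl in place of cyano on a saturated chain carbon bound to an aromatic nitrogen.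

Going by the values given here, one measured step bears on this place: no change at the digits printed from compound 2 to compound 3 (within the scatter). Among the compounds with values here, that exchange at the same carbon moved nothing, although it gives only a single comparison, and benzyloxycarbonyl has not been tested. The data show no sign of a shift in either direction, so no step beyond the scatter is expected in this assay, with a small chance of a gain that the data cannot exclude.

The expected step is no change at the digits printed from compound 3 to compound 4 (within the scatter). For compound 4 the estimated value is 10000 nM, with an expected range of 4000 nM to 20000 nM.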

Compound 4, half-maximal inhibitory concentration: 10000 nM
Compound 4: the middle estimate sits on the measured number at the digits printed; the range from low to high includes it.
By their numbers in this assay, from the lowest: compounds 1, 2, 3 and 4 (each within the scatter of the next).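

Along the saturated chain carbon bound to an aromatic nitrogen, this assay now gives a flat reading for a second exchange, and this one brings in a six-membered aromatic ring of carbon only: no change at the digits printed from compound 3 to compound 4 (within the scatter). The same holds one bond further out, where benzyloxy in place of diethylamino on a carbonyl carbon gives no change at the digits printed from compound 2 to compound 4 (within the scatter), so cyano, diethylcarbamoyl and benzyloxycarbonyl all read alike at this place. No measurement offered here accounts for this flat reading.

Still open, going by these compounds, is whether a free carboxylic acid or a primary amine at the end of this chain would move the reading beyond the scatter. Also open, on these data alone, is whether replacing the methoxy groups on the shared core with hydroxyl groups would do so, since every exchange read so far sits on the chain.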